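The compounds below may be only part of what the source reports. "The series", "measured", "known", "first", "only" and "open" are said of these compounds alone.

Working notes on the series. Compound 1 `O=S(=O)(/C=C/c1ccc(F)cc1)Cc1ccc(Nc2ncnc3ccccc23)cc1` and compound 2 `O=S(=O)(/C=C/c1ccc(Cl)cc1Cl)Cc1ccc(Nc2ncnc3ccccc23)cc1` share one core and differ only in the aryl on the double-bonded chain carbon. In a functional assay on the whole organism for antiproliferative activity, with Mus musculus as the target, in a xenograft, at a dose of 300 mg/kg (on this read-out lower numbers stand for less inhibition and higher numbers for more inhibition at the one dose given (going by the name of the read-out)), compound 1 gives 84%, whereas compound 2 gives 22%; the move to 2,4-dichlorophenyl in place of 4-fluorophenyl cost a number 62 percentage points lower from compound 1 to compound 2 (beyond the scatter). For the measured compounds named here, compound 2 therefore stands lowest of the two numbers measured so far, with compound 1 as its only neighbour. Compound 3 `O=S(=O)(/C=C/c1ccc(Cl)cc1Cl)Cc1ccc(Nc2ncnc3ccc(Br)cc23)cc1` keeps the 2,4-dichlorophenyl of compound 2 and adds (bromo in place of hydrogen on an aromatic carbon). Going by the values given here, no measured step touches this part of the shared core: the single step on record, a number 62 percentage points lower from compound 1 to compound 2 (beyond the scatter), concerns the other end of the molecule and gives no direction for a bromo on the fused ring. For compound 3 the expected step is a number 6 percentage points higher from compound 2 to compound 3 (within the scatter) in this assay, within the scatter. Compound 3 is estimated at 28%, with a range from 5% to 60%.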

Compound 3, a percentage reported as inhibition, in the whole organism at one dose (the size of the read-out at that dose, not a potency): 22%
The estimate for compound 3 lay 6 percentage points above the measured number; the measured number falls inside the stated range.
By their numbers in this assay, from the lowest: compounds 2 and 3 (each within the scatter of the next); then compound 1.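

In this assay, bromo in place of hydrogen, on an aromatic carbon of a six-membered aromatic ring of carbon only, gives no change at the digits printed from compound 2 to compound 3 (within the scatter). For the compounds shown here, this is the first reading on the shared core itself: with the 2,4-dichlorophenyl in place, this position takes a bromo and compound 2 and compound 3 stay within the scatter of each other, while the only step beyond the scatter remains the aryl change, a number 62 percentage points lower from compound 1 to compound 2 (beyond the scatter). Nothing on record bears on why the bromo leaves the number where it stands.

On these data alone, whether the same bromo would also sit within the scatter alongside the 4-fluorophenyl of compound 1 remains open. So does the outcome for other groups on this carbon, such as an amine or a methoxy, and a single dose says nothing about potency.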